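The source may hold more compounds than are shown below. What is called first, only, known or untested is meant among the compounds shown, and "the series" means these compounds.

For the measured compounds named here, compound 3 `COc1cccc(CNCCCNc2ccnc3cc(-c4ccccc4)ccc23)c1O` is one of three compounds measured in an ADME assay for permeability, using PAMPA, with a stated time of 30 min, at pH 7.4; a higher number here means that the compound crosses the layer faster, a lower number that the compound crosses the layer more slowly. In this assay compound 3 gives 237 10^-6 cm/s, level at the digits printed with compound 1 `c1ccc(-c2ccc3c(NCCCNCc4ccco4)ccnc3c2)cc1`, which gives 237 10^-6 cm/s. The third number comes from compound 2 `COc1ccc(F)cc1CNCCCNc1ccnc2cc(Oc3ccc(C(C)(C)C)cc3)ccc12`, which in this assay gives 317 10^-6 cm/s, a value within the scatter of compound 3. Going by the values given here, the single measured step, no change at the digits printed from compound 1 to compound 3 (within the scatter), swapped the group on the chain carbon bound to the amine nitrogen and left the read-out unchanged. Compound 4 `COc1cccc(CNCCCNc2ccnc3cc(Oc4ccc(C(C)(C)C)cc4)ccc23)c1O` differs from compound 3 by 4-(tert-butyl)phenoxy in place of phenyl on an aromatic carbon. Among the compounds with values here, no measured step changes this position of the shared core, but compound 2 already carries the same 4-(tert-butyl)phenoxy group, and its value in this assay lies within the scatter of the value of compound 3. The step of a 1.1-fold higher number from compound 3 to compound 4 (0.06 log units; within the scatter) is therefore expected to stay within the scatter, with no clear direction. Compound 4 is estimated at 270 10^-6 cm/s, with a range from 150 10^-6 cm/s to 450 10^-6 cm/s.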

Compound 4, apparent permeability: 317 10^-6 cm/s
The estimate for compound 4 lay 1.2-fold (0.07 log units) below the measured number; the range from low to high includes it.
By their numbers in this assay, from the lowest: compounds 1, 3, 2 and 4 (each within the scatter of the next).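

In this assay, the exchange at this aromatic carbon now has a direct reading: putting 4-(tert-butyl)phenoxy in place of phenyl gives a 1.3-fold higher number from compound 3 to compound 4 (0.13 log units; within the scatter), so a group of 11 heavy atoms instead of 6 leaves the read-out within the scatter in this pair. The group on the saturated chain carbon can also now be read with 4-(tert-butyl)phenoxy on the core: 2-hydroxy-3-methoxyphenyl in place of 5-fluoro-2-methoxyphenyl gives no change at the digits printed from compound 2 to compound 4 (within the scatter), the same outcome as the earlier exchange made with phenyl on the core. Nothing available explains why these numbers stay so close.

On these data alone, whether an amine or a carboxylic acid on this aromatic carbon would also stay within the scatter remains open. The same question stands for a longer chain in place of the present one.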